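Swapping the aryl ring on a urea nitrogen: compound 4

The compounds below may be only part of what the source reports. "The series", "measured", "known", "first", "only" and "open" are said of these compounds alone.

Measured so far:
Compound 1 `CSc1nc(C)nc(SC)c1NC(=O)N(Cc1ccc(Oc2ccc(F)cc2)cc1)C1CCCCCC1`: 56 nM
Compound 2 `CSc1cc(C)nc(Cl)c1NC(=O)N(Cc1ccc(Oc2ccc(F)cc2)cc1)C1CCCCCC1`: 46 nM
Compound 3 `CSc1cc(C)nc(S(C)(=O)=O)c1NC(=O)N(Cc1ccc(Oc2ccc(F)cc2)cc1)C1CCCCCC1`: 78 nM

All three were tested in an assay for inhibition of acyl-CoA:cholesterol acyltransferase (Oryctolagus cuniculus), using microsomes; a lower number here means a stronger inhibitor, a higher number a weaker inhibitor. Compound 2 has the lowest number of the three, but one of the two steps is only a 1.2-fold lower number from compound 1 to compound 2 (0.09 log units; within the scatter) and the other only a 1.7-fold higher number from compound 2 to compound 3 (0.23 log units; within the scatter), so on these numbers the three compounds are indistinguishable.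

Compound 4 `Cc1cc(C)c(NC(=O)N(Cc2ccc(Oc3ccc(F)cc3)cc2)C2CCCCCC2)c(C)n1` has not been measured yet. Compared with compound 2, the change is a group of 9 heavy atoms (8 carbon, 1 nitrogen; one six-membered aromatic ring with 1 hetero atom) in place of a group of 10 heavy atoms (7 carbon, 1 nitrogen, 1 sulfur, 1 chlorine; one six-membered aromatic ring with 1 hetero atom), on an amide-type nitrogen; the group that enters is 2,4,6-trimethylpyridin-3-yl, and it sits on the amide-type nitrogen whose other neighbour is the carbonyl carbon.

Within the data shown here, two measured steps bear on this. The step from compound 1 to compound 2 also replaced the whole ring on that nitrogen, and the step from compound 2 to compound 3 changed one group on the ring; both stayed within the scatter. The change to compound 4 is somewhat larger, removing both the methylthio and the chloro, so a slightly weaker inhibitor would not surprise, but no step beyond the scatter is expected in this assay. Compound 4 is therefore estimated at 85 nM, with a range from 30 nM to 250 nM, which corresponds to an expected step of a 1.8-fold higher number from compound 2 to compound 4 (0.27 log units; within the scatter).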

Compound 4, half-maximal inhibitory concentration: 62 nM
Compound 4: the middle estimate sits 1.4-fold (0.14 log units) above what was measured, and the stated range covers the measured number.
By their numbers in this assay, from the lowest: compounds 2, 1, 4 and 3 (each within the scatter of the next).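

In this assay, putting 2,4,6-trimethylpyridin-3-yl on the amide-type nitrogen gives a 1.3-fold higher number from compound 2 to compound 4 (0.13 log units; within the scatter) and, measured against the ring with two hetero atoms, a 1.1-fold higher number from compound 1 to compound 4 (0.04 log units; within the scatter) as well. Compounds 1, 2 and 3 all carry sulfur on this ring, so they could not show whether a number in this range depends on it; compound 4 has no sulfur or chlorine in this group, only carbon and one ring nitrogen, and it stays within the scatter of both neighbours, so among these compounds neither element is required at this position. Nothing measured here explains why such different groups give such similar numbers.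

The compounds shown leave open whether this position would accept a group of another kind, such as an amine or a carboxylic acid, in place of one of the methyl groups, or whether a step beyond the scatter would then appear. They also leave open whether an unsubstituted pyridin-3-yl or a plain phenyl ring on this nitrogen would stay within the same range in this assay or fall outside it.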